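Triazole nitrogen substituent swap in the chromene acid series

The source may report more compounds than this note shows. Statements on the series, on what has been measured and on what is new or still open speak of the compounds shown alone.

Among the measured compounds shown here, compound 2 `CCOC(=O)C1=Cc2ccccc2OC1(OCc1cn(-c2ccc(C)cc2)nn1)C(F)(F)F` gives 30200 nM in a functional assay on DU-145 cells (Homo sapiens) for inhibition, read by MTT assay, with a stated time of 24 h (a higher number here means a weaker inhibitor, a lower number a stronger inhibitor), the lowest of the three numbers so far, though its gap to compound 3 is within the scatter and only its gap to compound 1 is beyond it. Compound 1 `O=C(O)C1=Cc2ccccc2OC1(OCc1cc(-c2ccc(F)cc2)no1)C(F)(F)F` gives 168000 nM in this assay and compound 3 `COc1ccc(-c2cc(COC3(C(F)(F)F)Oc4ccccc4C=C3C(=O)O)on2)cc1` gives 42000 nM in this assay. For the measured compounds named here, the single measured step, a 4.0-fold lower number from compound 1 to compound 3 (0.60 log units; beyond the scatter) in this assay, concerns a substituent on the aryl ring of a different five-membered heterocycle and does not touch the position changed here.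

Compound 4 `CCOC(=O)C1=Cc2ccccc2OC1(OCc1cn(CC(=O)Nc2ccc(I)cc2Cl)nn1)C(F)(F)F` differs from compound 2 by ((2-chloro-4-iodophenyl)carbamoyl)methyl in place of 4-methylphenyl on an aromatic nitrogen. Going by the values given here, no measured pair shows a change at a ring nitrogen, and no pair exchanges an aryl group for a carbamoylmethyl chain, so the step has no direct precedent in this set; the only comparable change, at an aryl substituent, was modest. The number for compound 4 in this assay is therefore expected close to that of compound 2, with a 1.2-fold lower number from compound 2 to compound 4 (0.08 log units; within the scatter) as the estimated step and a wide range. The estimate for compound 4 in this assay is 25000 nM, between 7000 nM and 90000 nM.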

Compound 4, half-maximal inhibitory concentration: 24400 nM
For compound 4 the middle estimate is 1.0-fold (0.01 log units) above the measured one, and the stated range covers the measured number.
By their numbers in this assay, from the lowest: compounds 4, 2 and 3 (each within the scatter of the next); then compound 1.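

On the aromatic nitrogen of the five-membered aromatic ring with 3 nitrogen, replacing 4-methylphenyl with ((2-chloro-4-iodophenyl)carbamoyl)methyl gives a 1.2-fold lower number from compound 2 to compound 4 (0.09 log units; within the scatter) in this assay, so 12 heavy atoms in place of 7, with a hydrogen-bond donor and acceptor added, leave the number within the scatter. Among the compounds shown here, the earlier compounds offered only a step at an aryl substituent on a different five-membered ring, and this pair is the first reading at the ring nitrogen itself. Nothing available explains why these two groups read alike.

The chloro, the iodo and the carbamoylmethyl chain enter together, so their separate contributions cannot be read from this pair. From the compounds shown here alone, it remains open how a benzyl group or an aminoethyl chain on this nitrogen would read in this assay.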